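The compounds below may be only part of what the source reports. "The series", "measured", "known", "first", "only" and "open" are said of these compounds alone.

Compound 2 `COc1cccc(-n2cc3nc(-c4cccnc4C)n(C[C@H]4CCCN(CC5CCCCC5)C4)c(=O)c3n2)c1` gives the highest of the three numbers measured in an assay on HEK293 cells for displacement of a labelled ligand from growth hormone secretagogue receptor type 1 (Homo sapiens), with a stated time of 60 min (a lower number here means a stronger inhibitor, a higher number a weaker inhibitor), though its gap to compound 3 is within the scatter: compound 2 gives 200 nM, compound 3 `Cc1ncccc1-c1nc2cn(-c3ccccc3)nc2c(=O)n1C[C@H]1CCCN(C[C@H]2CCCO2)C1` gives 190 nM, and compound 1 `COc1ccc(-n2cc3nc(-c4cccnc4C)n(C[C@H]4CCCN(C[C@H]5CCCO5)C4)c(=O)c3n2)cc1` gives 52 nM. Compound 4 `COc1cccc(-n2cc3nc(-c4cccnc4C)n(C[C@H]4CCCN(CC(C)C)C4)c(=O)c3n2)c1` differs from compound 2 by isopropyl in place of cyclohexyl on a saturated chain carbon bound to an amine nitrogen in a ring. Among the measured compounds shown here, no measured step touches this part of the molecule; the only single-point step, a 3.7-fold higher number from compound 1 to compound 3 (0.56 log units; beyond the scatter), concerns the aromatic methoxy, and compound 1 and compound 2 differ in two places at once. For the measured compounds named here, with no precedent, a change in this assay of about the size of the scatter is expected, leaning toward a higher number, so compound 4 is expected to show a 1.6-fold higher number from compound 2 to compound 4 (0.20 log units; within the scatter). The estimate for compound 4 is 320 nM, within 120 nM to 850 nM.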

Compound 4, half-maximal inhibitory concentration: 5.7 nM
The estimate for compound 4 lay 56-fold (1.75 log units) above the measured number; the measured number lies below the stated range.
By their numbers in this assay, from the lowest: compound 4; then compound 1; then compounds 3 and 2 (each within the scatter of the next).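

In this assay, this position proves highly sensitive: with isopropyl in place of cyclohexyl on a saturated chain carbon bound to an amine nitrogen in a ring, the data show a 35-fold lower number from compound 2 to compound 4 (1.55 log units; beyond the scatter). Among the compounds shown here, the earlier compounds offered no step here, and this one is large, whereas the only earlier step, at the aromatic methoxy, is modest. No available evidence accounts for the size of this step.

A single pair cannot show whether the carbocyclic ring or its size drives the difference. Going by these compounds, how cyclopropyl, tert-butyl or a longer chain would behave at this place remains open.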